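The source may report more compounds than this note shows. Statements on the series, on what has been measured and on what is new or still open speak of the compounds shown alone.

Working notes on the cytotoxicity series.

The series shares one core; compound 1 `CC(C)CSc1nc(N)nc2c1ncn2/C=C1/CC1(CO)CO` carries an isobutylsulfanyl group, compound 2 `CCCCNc1nc(N)nc2c1ncn2/C=C1/CC1(CO)CO` a butylamino group and compound 3 `CCCCCCSc1nc(N)nc2c1ncn2/C=C1/CC1(CO)CO` a hexylsulfanyl group. In an ADME assay on MOLT-3 cells (Homo sapiens) for cytotoxicity, with a stated time of 7 days (a higher number here means that more compound is tolerated, a lower number that less compound is tolerated), compound 1 is recorded as "not determined" (no result reported). In this assay compound 2 reaches only a limit, > 20000 nM. Compound 3 likewise reaches only a limit in this assay, > 20000 nM. Among the compounds with values here, the one step among the measured compounds, a step that the two limits leave unreadable from compound 2 to compound 3, cannot be sized, since both ends are limits; what can be said rests on (the limit of > 20000 nM in this assay, at which 2 of the 3 values shown sit).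

Within the data shown here, compound 3 therefore stands at the limit of this assay, with nothing among the measured compounds placing it above or below any other.

Compound 4 `CCOc1nc(N)nc2c1ncn2/C=C1/CC1(CO)CO` differs from compound 3 by ethoxy in place of hexylsulfanyl on an aromatic carbon. Among the measured compounds shown here, no measured step gives the size of a change of this kind, and the only measured step bearing on a change at this carbon is unreadable. The expectation for compound 4 is that the step that the limit leaves unreadable from compound 3 to compound 4 stays within the scatter, given that compound 3 sits at > 20000 nM and compound 2 at the same limit. Compound 4 is estimated at 25000 nM in this assay, with a range from 8000 nM to 100000 nM, most likely reported again as a limit.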

Compound 4, half-maximal cytotoxic concentration: > 20000 nM
Compound 4 was reported as a limit; the forecaster's own chance of this, stated with the estimate: 80%; the middle value lies beyond the limit too.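

Within the data shown here, compound 2, compound 3 and compound 4 all sit at limits in this assay and no new step among them can be read. The compounds shown leave open whether any group on this aromatic carbon gives a half-maximal cytotoxic concentration that can be read as a number rather than as a limit.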